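The source may hold more compounds than are shown below. What is called first, only, known or untested is meant among the compounds shown, and "the series" means these compounds.

Working notes on the series.

Compound 1 `COc1ccc(-c2[nH]c3ccc(C(C)C)cc3c2C=O)cc1` is the reference. In a functional assay on MDA-MB-231 cells (Homo sapiens) for antiproliferative activity, with a stated time of 4 days (a higher number here means a weaker inhibitor, a lower number a stronger inhibitor), compound 1 gives 29 nM. Among the compounds with values here, compound 2 `COc1ccc(-c2[nH]c3ccc(C(C)(C)C)cc3c2C=O)cc1` carries the change (methyl in place of hydrogen on a saturated chain carbon bound to an aromatic carbon and two saturated chain carbons); in this assay compound 2 gives 280 nM, and the step of a 9.7-fold higher number from compound 1 to compound 2 (0.98 log units; beyond the scatter) is the only measured example of that change among the compounds here.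

Compound 3 `CCCCc1ccc2[nH]c(-c3ccc(OC)cc3)c(/C=N\C)c2c1` has a different core, and the difference between the core of compound 3 and the core of compound 1 is not broken down here. In this assay compound 3 gives 6 nM, the lowest number of the three measured, beyond the scatter from both compound 1 and compound 2.

Compound 4 `CCCCCc1ccc2[nH]c(-c3ccc(OC)cc3)c(/C=N\C)c2c1` is not yet measured. It differs from compound 3 by methyl in place of hydrogen on a saturated chain carbon, four bonds along the chain from an aromatic carbon. This is the same kind of change as from compound 1 to compound 2, but not the same: there the entering methyl sits on a saturated chain carbon bound to an aromatic carbon and two saturated chain carbons, here on a saturated chain carbon, four bonds along the chain from an aromatic carbon. The measured step gives only a loose guide, since its surroundings differ. A smaller step is expected, a 1.5-fold higher number from compound 3 to compound 4 (0.18 log units; within the scatter), set beside the earlier one because compound 3 already gives 6 nM and chain lengthening is not represented among the measured pairs. Compound 4 is estimated at 9 nM, expected between 3 nM and 30 nM.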

Compound 4, half-maximal inhibitory concentration: 6 nM
Compound 4: middle estimate off by 1.5-fold (0.18 log units), on the high side; the range from low to high includes it.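

Methyl in place of hydrogen gives no change at the digits printed from compound 3 to compound 4 (within the scatter) in this assay. Set beside the earlier step, the size of this change does not carry over unaltered from one core to the other in this series: the same change on two cores in this assay, a 9.7-fold higher number (0.98 log units; beyond the scatter) from compound 1 to compound 2 and no change at the digits printed (within the scatter) from compound 3 to compound 4, 9.7-fold (0.98 log units) apart, beyond the scatter of two such steps

This does not show that the core alone separates the two steps: the entering methyl also sits at a different place in each, on a saturated chain carbon bound to an aromatic carbon and two saturated chain carbons in compound 2, and on a saturated chain carbon, four bonds along the chain from an aromatic carbon, in compound 4, and each step rests on a single pair.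

Open, as far as these compounds go, is whether the same place on the chain gives the same result on the core of compound 1, and whether a longer chain on the core of compound 3 still leaves the number unmoved in this assay. Also open, from the compounds shown here alone, is how an amine or a carboxylic acid in place of the chain would read there.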